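Amide-tail variation in a glutathione transferase inhibition series

This account rests on a few compounds, and the source may have more. Where it says the series, first, only, none or still open, it means among the compounds named here.

Measured so far in an assay on isolated protein for inhibition of glutathione S-transferase P (Homo sapiens), with a stated time of 10 min; a higher number here means a weaker inhibitor, a lower number a stronger inhibitor:
Compound 1 `Cc1ccccc1NC(=O)CCC(=O)OCCCCCCSc1ccc([N+](=O)[O-])c2nonc12` gives 4100 nM.
Compound 2 `O=C(CCC(=O)OCCCCCCSc1ccc([N+](=O)[O-])c2nonc12)Nc1ccc(F)c(Cl)c1` gives 9850 nM.
Compound 3 `CCN(CC)CCCNC(=O)CCC(=O)OCCCCCCSc1ccc([N+](=O)[O-])c2nonc12` gives 9550 nM.

Compound 3 stands second highest of the three numbers. Its value and that of compound 2 lie within the scatter of each other, so nothing separates them, while a 2.3-fold higher number from compound 1 to compound 3 (0.37 log units; beyond the scatter). All measured steps sit on the amide-type nitrogen: a 2.4-fold higher number from compound 1 to compound 2 (0.38 log units; beyond the scatter), a 2.3-fold higher number from compound 1 to compound 3 (0.37 log units; beyond the scatter) and a 1.0-fold lower number from compound 2 to compound 3 (0.01 log units; within the scatter). Swapping the aryl or aminoalkyl group on that nitrogen has moved this assay only modestly at most.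

Compound 4 `O=C(CCC(=O)OCCCCCCSc1ccc([N+](=O)[O-])c2nonc12)NCCN1CCCC1` differs from compound 3 in pyrrolidin-1-yl in place of (diethylamino)methyl on a saturated chain carbon, two bonds along the chain from an amide-type nitrogen. Among the compounds with values here, no measured step alters the amine tail itself; the only step that exchanges the tail for something else, a 1.0-fold lower number from compound 2 to compound 3 (0.01 log units; within the scatter), lies within the scatter. Closing the terminal amine into a five-membered ring while keeping one acceptor and no donor is a smaller change than any measured step, so in this assay no step beyond the scatter is expected, in either direction. For compound 4 the expected value in this assay is 9000 nM, with a range from 4500 nM to 18000 nM. This expectation amounts to a step of a 1.1-fold lower number from compound 3 to compound 4 (0.03 log units; within the scatter).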

Compound 4, half-maximal inhibitory concentration: 460 nM
Estimate against measurement, compound 4: 20-fold (1.29 log units) above; measured number below the stated range.
By their numbers in this assay, from the lowest: compound 4; then compound 1; then compounds 3 and 2 (each within the scatter of the next).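

In this assay, within the data shown here, the amide-type nitrogen proves far more sensitive than the earlier compounds indicated: with 2-(pyrrolidin-1-yl)ethyl in place of 3-(diethylamino)propyl, the result is a 21-fold lower number from compound 3 to compound 4 (1.32 log units; beyond the scatter), a large step where earlier exchanges were modest at most. The same tail also stands clear of both aryl amides, with a 21-fold lower number from compound 2 to compound 4 (1.33 log units; beyond the scatter) and an 8.9-fold lower number from compound 1 to compound 4 (0.95 log units; beyond the scatter), so compound 4 holds the lowest number of the four, beyond the scatter of each of the others. An amine-bearing tail alone does not account for this pattern, as compound 3 goes against it by remaining within the scatter of the aryl amide compound 2.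

No available evidence gives a reason for the size of this step. The step changes the terminal amine and the chain carrying it together, so 3-(pyrrolidin-1-yl)propyl and 2-(diethylamino)ethyl on the same nitrogen would be needed to separate the two changes, and a 2-(piperidin-1-yl)ethyl tail would show whether the five-membered ring itself matters.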